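The source may report more compounds than this note shows. Statements on the series, on what has been measured and on what is new or still open speak of the compounds shown alone.

Compound 1 `ClCc1ccc(Cn2cnc3c(Cl)ncnc32)cc1`: > 100000 nM
Compound 2 `Nc1nc(Cl)c2ncn(Cc3ccc(CCl)cc3)c2n1`: > 100000 nM
Compound 3 `ClCc1ccccc1Cn1cnc2c(Cl)ncnc21`: > 100000 nM

In a functional assay on MOLT-4 cells (Homo sapiens) for cytotoxicity, read by sulforhodamine B assay, with a stated time of 48 h (a higher number here means that more compound is tolerated, a lower number that less compound is tolerated), compound 1 gives > 100000 nM, which is a limit of the assay and not a number. Compound 2 likewise gives only a limit, > 100000 nM. Compound 3 too gives only a limit, > 100000 nM. All three values sit at the limit of > 100000 nM in this assay, at which 3 of the 3 values shown sit. From compound 1 to compound 2 the change is amino in place of hydrogen on an aromatic carbon and the step it made is a step that the two limits leave unreadable from compound 1 to compound 2. Compound 4 `Nc1nc(Cl)c2ncn(Cc3ccccc3CCl)c2n1` has not yet been measured in this assay. It differs from compound 3 by amino in place of hydrogen on an aromatic carbon, the same change as from compound 1 to compound 2, at the same kind of place in the ring. The difference between the two cores, that of compound 1 and that of compound 3, is not broken down here. Because a step that the two limits leave unreadable from compound 1 to compound 2 is hidden by the limit on both sides, and because the limit of > 100000 nM in this assay, at which 3 of the 3 values shown sit, is also where compound 3 sits, the step for compound 4 is expected to be a step that the limit leaves unreadable from compound 3 to compound 4, most likely giving again only a limit. Compound 4 is therefore expected to give roughly 150000 nM in this assay, with a range from 50000 nM to 500000 nM.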

Compound 4, concentration lethal to 50% of the cells: > 100000 nM
Compound 4 ended at the assay's limit; the forecaster's own chance of this, stated with the estimate: 85%; the middle value lies beyond the limit too.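

No new step can be read between compound 3 and compound 4, because each gives only a limit of the assay and not a number: the limit of > 100000 nM in this assay, at which 4 of the 4 values shown sit.

The compounds shown leave open whether amino in place of hydrogen changes anything in this assay, and what lethal concentration any of the four actually has.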